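An isopropyl group added to compound 1

This account rests on a few compounds, and the source may have more. Where it says the series, first, only, none or still open, it means among the compounds named here.

For the measured compounds named here, in a functional assay (thoracic aorta) for inhibition, with Rattus norvegicus as the target (on this read-out higher numbers stand for weaker inhibition and lower numbers for stronger inhibition), compound 1 `O=C(O)c1cc(CCCCCNS(=O)(=O)c2ccccc2)c2cccccc1-2` gives 840 nM as its reading, the second highest of the three numbers measured so far. Compound 2 `CC(C)c1ccc2c(CCCNS(=O)(=O)c3ccccc3)cc(C(=O)O)c-2cc1` reads higher at 4800 nM and compound 3 `CC(C)c1ccc2c(CCCCCNS(=O)(=O)c3ccccc3)cc(C(=O)O)c-2cc1` reads lower at 120 nM in the same test. Both gaps to compound 1 lie beyond the scatter.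

Compound 4 `CC(C)c1cccc2c(CCCCCNS(=O)(=O)c3ccccc3)cc(C(=O)O)c-2c1` has not yet been measured. It differs from compound 1 by a single change: isopropyl in place of hydrogen on an aromatic carbon with the rest of the structure left as it is. Going by the values given here, one measured step bears on this: a 7.0-fold lower number from compound 1 to compound 3 (0.85 log units; beyond the scatter) for the same exchange of hydrogen for isopropyl on an aromatic carbon, a modest step beyond the scatter. Among the compounds with values here, compound 3 and compound 4 carry the isopropyl on different carbons, and no measurement yet shows what that difference is worth. Only part of the earlier step is therefore assumed to carry over, so a somewhat smaller step in the same direction, towards stronger inhibition, is expected in this assay for this pair. The expected step is a 3.0-fold lower number from compound 1 to compound 4 (0.48 log units; beyond the scatter) on this reasoning. For compound 4 the estimated value is 280 nM with an expected range from 80 nM to 950 nM around it.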

Compound 4, half-maximal inhibitory concentration: 2600 nM
The estimate for compound 4 lay 9.3-fold (0.97 log units) below the measured number, and the stated range ends below it.
By their numbers in this assay, from the lowest: compound 3; then compound 1; then compounds 4 and 2 (each within the scatter of the next).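

In this assay the exchange of hydrogen for isopropyl has no single direction on the core of compound 1: this time it gives a 3.1-fold higher number from compound 1 to compound 4 (0.49 log units; beyond the scatter) where the same exchange on a different aromatic carbon gave a 7.0-fold lower number from compound 1 to compound 3 (0.85 log units; beyond the scatter) and so moved the other way. The earlier gain therefore belonged to isopropyl on one particular carbon and not to isopropyl as such, and among these compounds the choice of carbon alone separates compound 3 at 120 nM from compound 4 at 2600 nM on the otherwise unchanged structure. Nothing at hand explains why the two carbons part in this way.

The compounds shown leave open whether a methyl group, a tert-butyl group or a chlorine atom on these same carbons would move the number as isopropyl does, and what isopropyl is worth on the other carbons of the seven-membered aromatic ring. They also leave open whether the carbon carrying isopropyl in compound 4 would keep its standing with the shorter chain of compound 2, or with a longer chain than any seen here.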